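The source may hold more compounds than are shown below. What is called first, only, known or untested is meant among the compounds shown, and "the series" means these compounds.

Compound 1 `CCOc1nc2cccc(C(=O)Nc3ccccc3)c2n1Cc1ccc(-c2ccccc2-c2nnn[nH]2)cc1` was tested in an assay on isolated protein for inhibition of NEDD8-activating enzyme E1 regulatory subunit (Homo sapiens), read by Western blot, with stated times of 10 min and 30 min, tested at 25 uM (a higher number here means more inhibition at the concentration tested (going by the name of the read-out), a lower number less inhibition), where compound 1 gives 34.6%. Its companion compound 2 `CCOc1nc2cccc(C(=O)NC(c3ccccc3)c3ccccc3)c2n1Cc1ccc(-c2ccccc2-c2nnn[nH]2)cc1` gives 35.7% in this assay, a number within the scatter of compound 1, so the two stand together and neither can be set above the other. The next compound, compound 3 `CCOc1nc2cccc(C(=O)NOCc3ccccc3)c2n1Cc1ccc(-c2ccccc2-c2nnn[nH]2)cc1`, differs from compound 1 in a single place: benzyloxy in place of phenyl on an amide-type nitrogen. For the measured compounds named here, no measured pair shows this change, so no step size is known for it. Compound 3 is therefore expected to give 35%, within 20% to 50%, with an estimated step of a number 0.4 percentage points higher from compound 1 to compound 3 (within the scatter) that stays within the scatter in either direction.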

Compound 3, a percentage reported as inhibition, at one concentration (the size of the read-out at that concentration, not a potency): 39.8%
Estimate against measurement, compound 3: 4.8 percentage points below; the range from low to high includes it.
By their numbers in this assay, from the lowest: compounds 1, 2 and 3 (each within the scatter of the next).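

Putting benzyloxy in place of phenyl on the amide-type nitrogen gives a step in this assay of a number 5.2 percentage points higher from compound 1 to compound 3 (within the scatter), so this first reading of the change shows no difference that can be told from the scatter. The nitrogen carries the benzyloxy group, with its added oxygen, and the inhibition stays in the same range. Nothing measured here bears on why this is so.

Left open is whether a phenethyl group, with carbon where benzyloxy has its oxygen, would read the same. Also open, from the compounds shown here alone, is whether a chain ending in an amine or a carboxylic acid on this nitrogen would move the number beyond the scatter.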